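Adding a 1,3-thiazol-5-yl group to an inactive series

The source may report more compounds than this note shows. Statements on the series, on what has been measured and on what is new or still open speak of the compounds shown alone.

Compound 1 `Cc1cc(Nc2cccc(Cl)c2)nc(N)n1`: > 180000 nM
Compound 2 `Cc1cc(Nc2cccc(Br)c2)nc(N)n1`: > 180000 nM
Compound 3 `Cc1cc(Nc2cccc(Cl)c2Cl)nc(N)n1`: > 180000 nM

All three compounds share one core and were tested in an assay on cells for inhibition of S-adenosylmethionine decarboxylase proenzyme (Homo sapiens), read by mass spectrometry, at pH 7.2; on this read-out lower numbers stand for stronger inhibition and higher numbers for weaker inhibition. For compound 1 the value shown is a limit of the assay and not a measured number. Compound 2 likewise stands only at a limit. Compound 3 too gives no number beyond a limit. Taken together this is the limit of > 180000 nM in this assay, at which 3 of the 3 values shown sit, so none of the three can be ranked against the others.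

The step that the two limits leave unreadable from compound 1 to compound 2 has no readable size, and the same is true of the step that the two limits leave unreadable from compound 1 to compound 3. Neither swapping one halogen for another nor adding a second chloro group moved any compound off the limit, but whether they changed anything underneath it cannot be seen.

Compound 4 `Cc1cc(Nc2cc(Cl)cc(-c3cncs3)c2)nc(N)n1` differs from compound 1 by 1,3-thiazol-5-yl in place of hydrogen on an aromatic carbon. This is a larger addition than either measured step, and nothing measured bears directly on it.

With no readable step to lean on, compound 4 is expected to stay weak, with an estimated step of an at least 2.0-fold lower number from compound 1 to compound 4 (0.30 log units; that floor lies within the scatter). The expected value for compound 4 in this assay is 90000 nM, within an estimated range from 8000 nM to 400000 nM.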

Compound 4, half-maximal inhibitory concentration: > 21000 nM
Compound 4 was reported as a limit; the forecaster's own chance of this, stated with the estimate: 55%; the middle value does not contradict the limit.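

In this assay compound 4 gives only a limit, > 21000 nM. Among these compounds, compound 1 also gives only a limit, > 180000 nM, and no step between it and compound 4 can be read from the two. On these data alone, whether 1,3-thiazol-5-yl in place of hydrogen changes inhibition at all, and how compounds 1 to 4 rank, stays open.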